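A few compounds are considered here, and "the series" means these few. Any claim that something is new, unique, unknown or untested is made for them only; others in the source may bear on it.

Of the compounds shown here, three sharing one core have been measured in an assay on LtK cells with ATP-sensitive inward rectifier potassium channel 11 (Homo sapiens) as the target; a lower number here means that less compound is needed, a higher number that more compound is needed for the effect. Compound 1 `C/C=C/C(=O)Nc1c(C(O)(C(F)(F)F)C(F)(F)F)ccc2ccccc12` gives 72 nM. Compound 2 `CC(C)OC(=O)Nc1c(C(O)(C(F)(F)F)C(F)(F)F)ccc2ccccc12`, which carries an isopropoxy group on the carbonyl carbon, gives 1160 nM, and compound 3 `O=C(Nc1c(C(O)(C(F)(F)F)C(F)(F)F)ccc2ccccc12)c1ccccc1Cl`, with a 2-chlorophenyl group in the same place, gives 2040 nM. Compound 3 thus shows the highest of the three numbers, though the value of compound 2 lies within the scatter of it; only compound 1 is separated from it by a gap beyond the scatter.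

All measured steps concern the group on that carbonyl carbon. There is a 16-fold higher number from compound 1 to compound 2 (1.21 log units; beyond the scatter) and a 28-fold higher number from compound 1 to compound 3 (1.45 log units; beyond the scatter), both large, while a 1.8-fold higher number from compound 2 to compound 3 (0.25 log units; within the scatter) stays within the scatter.

Compound 4 `O=C(Nc1c(C(O)(C(F)(F)F)C(F)(F)F)ccc2ccccc12)c1cccc([N+](=O)[O-])c1` differs from compound 3 in one place: 3-nitrophenyl in place of 2-chlorophenyl on a carbonyl carbon. Among the measured compounds shown here, no measured step exchanges one aryl group for another. The closest guide is a 1.8-fold higher number from compound 2 to compound 3 (0.25 log units; within the scatter), which shows that an alkoxy group and an aryl group in this position give numbers close to each other and far from compound 1. A second aryl group is therefore expected to leave the number near that of compound 3, with a 1.2-fold higher number from compound 3 to compound 4 (0.09 log units; within the scatter) as the expected change, not beyond the scatter. Compound 4 is estimated at 2500 nM, within a range from 800 nM to 8000 nM.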

Compound 4, half-maximal effective concentration: 117 nM
The estimate for compound 4 lay 21-fold (1.33 log units) above the measured number; the measured number lies below the stated range.
By their numbers in this assay, from the lowest: compounds 1 and 4 (each within the scatter of the next); then compounds 2 and 3 (each within the scatter of the next).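

In this assay, two aryl groups on this carbonyl carbon do not behave alike: there is a 17-fold lower number from compound 3 to compound 4 (1.24 log units; beyond the scatter), so the presence of an aryl group alone does not set the number. The 3-nitrophenyl group also stands apart from the isopropoxy group, with a 9.9-fold lower number from compound 2 to compound 4 (1.00 log units; beyond the scatter), while a 1.6-fold higher number from compound 1 to compound 4 (0.21 log units; within the scatter) puts it level with the prop-1-en-1-yl group. A low number at this position therefore no longer rests on prop-1-en-1-yl alone, as a group with an aromatic ring reaches the same level.

The 2-chlorophenyl and 3-nitrophenyl groups differ both in the substituent and in where it sits on the ring, so a 3-chlorophenyl or 2-nitrophenyl group, together with a plain phenyl group, would be needed to tell these two changes apart. Nothing available here accounts for the gap between compound 3 and compound 4.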